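Replacing a Piperazinylmethyl Group: Expected Tolerance in MT4 Cells

The source may report more compounds than this note shows. Statements on the series, on what has been measured and on what is new or still open speak of the compounds shown alone.

Measured compounds:
compound 1 `Cc1cc(/C=C/C#N)cc(C)c1Oc1nc(Nc2ccc(N3CCN(S(N)(=O)=O)CC3)cc2)nc2ccsc12`: > 222000 nM
compound 2 `Cc1cc(/C=C/C#N)cc(C)c1Oc1nc(Nc2ccc(CN3CCNCC3)cc2)nc2sccc12`: 4030 nM

Among the measured compounds shown here, in an ADME assay on MT4 cells (Homo sapiens) for cytotoxicity, read by MTT assay, with a stated time of 5 days (a higher number here means that more compound is tolerated, a lower number that less compound is tolerated), compound 2 gives 4030 nM, the only number among the two values shown. Compound 1 gives > 222000 nM, which is a limit of the assay rather than a number (the limit of > 222000 nM in this assay, at which 1 of the 2 values shown sits). Compound 3 `Cc1cc(/C=C/C#N)cc(C)c1Oc1nc(Nc2ccc(N3CCCC(NS(C)(=O)=O)C3)cc2)nc2sccc12` is not yet measured; it differs from compound 2 by 3-(methanesulfonamido)piperidin-1-yl in place of (piperazin-1-yl)methyl on an aromatic carbon. For the measured compounds named here, no step between two measured compounds is available, so the size of this change cannot be read from a measured pair. A moderate upward step is expected from compound 2 to compound 3, a 7.4-fold higher number from compound 2 to compound 3 (0.87 log units; beyond the scatter). Compound 3 is estimated at 30000 nM, with a range from 6000 nM to 222000 nM.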

Compound 3, half-maximal cytotoxic concentration: 112000 nM
Compound 3: middle estimate off by 3.7-fold (0.57 log units), on the low side, within the range that was stated.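

In this assay, swapping (piperazin-1-yl)methyl for 3-(methanesulfonamido)piperidin-1-yl gives a 28-fold higher number from compound 2 to compound 3 (1.44 log units; beyond the scatter). Among the compounds shown here, this is the first step that can be read at this place, and it shows that changing this one group on the shared core can by itself shift cell tolerance considerably. Nothing measured here accounts for the size of this step. The compounds shown leave open which part of the entering group matters. A plain piperidin-1-yl group, or a piperidine carrying a simple amine, would help separate the ring from the methanesulfonamido group.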